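Hydroxy removal on the chain of the lactone series

A few compounds are considered here, and "the series" means these few. Any claim that something is new, unique, unknown or untested is made for them only; others in the source may bear on it.

Compound 2 `CCCCC[C@H](C[C@H](O)C[C@H]1CC=CC(=O)O1)OC` is tested in a functional assay on A2780 cells (Homo sapiens) for cytotoxicity, read by MTT assay, with a stated time of 24 h (a higher number here means a weaker inhibitor, a lower number a stronger inhibitor), where compound 2 gives 44000 nM. This is the highest of the two numbers available: compound 1 `CCCCC[C@@H](CCC[C@H]1CC=CC(=O)O1)OC` gives 20600 nM in this assay, and the gap between the two stands beyond the usual scatter, so compound 2 is the weaker of the pair.

Compound 3 `CCCCC[C@H](CCC[C@H]1CC=CC(=O)O1)OC` is not yet measured. It differs from compound 2 in one place: hydrogen in place of hydroxy on a saturated chain carbon bound to two saturated chain carbons. Within the data shown here, no measured pair shows this change, so its effect cannot be read from the data. The change removes one heavy atom and a donor-acceptor pair without touching the core; a moderate step is expected, toward a lower number, though none beyond the scatter would not surprise. The step from compound 2 to compound 3 is estimated at a 2.0-fold lower number from compound 2 to compound 3 (0.30 log units; within the scatter). Compound 3 is expected to give about 22000 nM, within 8000 nM to 60000 nM.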

Compound 3, half-maximal inhibitory concentration: 17100 nM
The estimate for compound 3 lay 1.3-fold (0.11 log units) above the measured number, and the stated range covers the measured number.
By their numbers in this assay, from the lowest: compounds 3 and 1 (each within the scatter of the next); then compound 2.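

In this assay, the hydroxy on this saturated chain carbon now has a measured effect: replacing it with hydrogen gives a 2.6-fold lower number from compound 2 to compound 3 (0.41 log units; beyond the scatter), a modest step beyond the scatter, and the pair shows that the hydroxy is not needed for activity in this assay. The stereocentre at a saturated chain carbon, drawn S in compound 1 and R in compound 3, shows no effect beyond the scatter, with a 1.2-fold lower number from compound 1 to compound 3 (0.08 log units; within the scatter). This comparison isolates that one centre: the fact that compounds 1 and 3 differ only in the configuration as drawn

As far as these compounds go, how an amine or a fluorine on the same carbon would compare with hydrogen and hydroxy remains open. From the compounds shown here alone, the hydroxy step rests on a single pair, and whether it holds with the other configuration at the stereocentre also remains open.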